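A few compounds are considered here, and "the series" means these few. Any claim that something is new, unique, unknown or untested is made for them only; others in the source may bear on it.

Working notes on a small anilinomethyl-imidazole series, cytotoxicity toward mouse fibroblasts. Three members are measured so far. Compound 1 `Clc1ccc(NCc2cncn2Cc2ccc(-c3ccccc3)cc2)cc1-c1ccccc1` carries a biphenyl on the benzyl arm and a chloro on the aniline side; in a toxicity assay on NIH3T3 cells (Mus musculus) for cytotoxicity, read by resazurin assay (a lower number here means that less compound is needed, a higher number that more compound is needed for the effect), compound 1 gives > 1000 nM, which is a limit of the assay and not a number. Compound 2 `COC(=O)c1ccc(NCc2cncn2Cc2cccc(C)c2)cc1-c1ccccc1` has a methyl ester on the aniline side and a 3-methylbenzyl group; in this assay compound 2 gives > 10000 nM, again a limit of the assay rather than a measured number. Compound 3 `O=[N+]([O-])c1ccc(Cn2cncc2CNc2cccc(-c3ccccc3)c2)cc1` bears a nitro group on the benzyl arm; in this assay compound 3 gives 10000 nM.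

Where compound 2 stands is therefore set by a limit, not by a number: two of the three values are limits, one at the limit of > 1000 nM in this assay, at which 1 of the 3 values shown sits, and one at the limit of > 10000 nM in this assay, at which 1 of the 3 values shown sits, and compound 2 sits at the higher of these. Nothing in the set shows a measurable cytotoxic effect at the concentrations covered.

Compound 4 `COC(=O)c1ccc(NCc2cncn2Cc2cccc(C#N)c2)cc1-c1ccccc1` differs from compound 2 by cyano in place of methyl on an aromatic carbon. Within the data shown here, no pair of measured compounds shares this change, so there is no measured step to calibrate it. Given that compound 2 gives > 10000 nM, a limit, the change is not expected to bring the value into the measurable range. The expected step is a step that the limit leaves unreadable from compound 2 to compound 4, within the scatter. Compound 4 is expected to give about 15000 nM in this assay, most probably reported again as a limit. The expected range for compound 4 runs from 5000 nM to 50000 nM.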

Compound 4, half-maximal effective concentration: > 10000 nM
Compound 4 gave a limit, no number; the forecaster's own chance of this, stated with the estimate: 80%; the middle value is on the limit's open side.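

In this assay compound 2 gives > 10000 nM, a limit of the assay and not a number. Compound 4 gives > 10000 nM, again a limit, so no step can be read between compound 2 and compound 4. The compounds shown leave open whether cyano in place of methyl on an aromatic carbon changes the cytotoxicity of this series at all.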